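Swapping a phenyl for a second furan-2-yl on a shared core

This account rests on a few compounds, and the source may have more. Where it says the series, first, only, none or still open, it means among the compounds named here.

Of the compounds shown here, two with the same fused core have been measured so far. Compound 1 `Nc1nc(-c2ccccc2)cn2cc(-c3ccco3)nc12` carries a phenyl on one ring and a furan-2-yl on the other; in an assay on cells for displacement of a labelled ligand from transmembrane domain-containing protein TMIGD3 (Homo sapiens), read by scintillation counting, with a stated time of 120 min, tested at 1 uM (on this read-out lower numbers stand for less inhibition and higher numbers for more inhibition at the one concentration tested (going by the name of the read-out)), compound 1 gives 21%. Compound 2 `Nc1nc(-c2ccco2)cn2cc(-c3ccccc3)nc12` has the same two groups in exchanged positions, and in this assay compound 2 gives 20%. The two results sit side by side and lie within the scatter of each other, so there is no real separation between compound 1 and compound 2 on this read-out.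

Compound 3 `Nc1nc(-c2ccco2)cn2cc(-c3ccco3)nc12` has not yet been measured. It differs from compound 2 in one place: furan-2-yl in place of phenyl on an aromatic carbon. The two measured compounds show that exchanging where the phenyl and the furan-2-yl sit leaves the read-out essentially unchanged, which gives no sign that a furan-2-yl in place of the phenyl should move the number beyond the scatter. The step from compound 2 to compound 3 is therefore expected to be small, no change at the digits printed from compound 2 to compound 3 (within the scatter), in no particular direction. For compound 3 the expected result in this assay is 20%, with a range from 5% to 38%.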

Compound 3, a percentage reported as inhibition, at one concentration (the size of the read-out at that concentration, not a potency): 38%
Compound 3: the middle estimate sits 18 percentage points below what was measured, and the stated range covers the measured number.
By their numbers in this assay, from the lowest: compounds 2 and 1 (each within the scatter of the next); then compound 3.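

In this assay, furan-2-yl in place of phenyl on an aromatic carbon of a five-membered aromatic ring with 2 nitrogen gives a number 18 percentage points higher from compound 2 to compound 3 (beyond the scatter), so this position responds to the change in a way that the exchange of the two groups between compound 1 and compound 2 could not show. The same replacement at the other group-bearing place on the shared core gives a number 17 percentage points higher from compound 1 to compound 3 (beyond the scatter), so both steps lie beyond the scatter and compound 3, with furan-2-yl at both places and no phenyl, stands highest of the three. No measurement at hand says what lies behind this rise.

Going by these compounds, what remains open is whether the rise depends on furan-2-yl itself or on the loss of phenyl, which a thiophen-2-yl, a pyridine ring or a simple methyl at these places could help to separate. The read-out also comes from a single concentration, so these compounds leave open how the steps would translate into potency.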